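Trifluoromethyl in place of methoxycarbonyl: expecting compound 4

The compounds below may be only part of what the source reports. "The series", "measured", "known", "first", "only" and "open" are said of these compounds alone.

Measured in a physicochemical assay for solubility, at pH 7.4; on this read-out higher numbers stand for higher solubility and lower numbers for lower solubility:
Compound 1 `Cc1cc(NC(=O)Nc2cccc(C(N)=O)c2)c2ccccc2n1`: 100 nM
Compound 2 `Cc1cc(NC(=O)Nc2cccc(F)c2)c2ccccc2n1`: 100 nM
Compound 3 `COC(=O)c1cccc(NC(=O)Nc2cc(C)nc3ccccc23)c1`: 600 nM

Compound 3, at 600 nM, gives the highest number of the three, and its gaps to both other compounds lie beyond the scatter. Compound 4 `Cc1cc(NC(=O)Nc2cccc(C(F)(F)F)c2)c2ccccc2n1` has not yet been measured. It carries trifluoromethyl in place of methoxycarbonyl on an aromatic carbon of a six-membered aromatic ring of carbon only, meta to a large group: trifluoromethyl in place of methoxycarbonyl on an aromatic carbon.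

Going by the values given here, three measured steps bear on this change. The closest is a 6.0-fold higher number from compound 2 to compound 3 (0.78 log units; beyond the scatter), with methoxycarbonyl in place of fluoro on an aromatic carbon. A second is a 6.0-fold higher number from compound 1 to compound 3 (0.78 log units; beyond the scatter), with methoxy in place of amino on a carbonyl carbon. The third is no change at the digits printed from compound 1 to compound 2 (within the scatter), with fluoro in place of carbamoyl. Among these compounds, only the methoxycarbonyl compound stands apart. Among the compounds with values here, no measured compound carries trifluoromethyl, so the data do not fix where it will fall. A move back towards compound 2, at 100 nM, is nevertheless the likeliest outcome in this assay. The expected change is a 3.3-fold lower number from compound 3 to compound 4 (0.52 log units; beyond the scatter), an estimate slightly smaller than the measured steps. For compound 4 the estimated value is 180 nM, with an expected range from 60 nM to 500 nM.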

Compound 4, solubility: 100 nM
Compound 4: the middle estimate sits 1.8-fold (0.26 log units) above what was measured; the measured number falls inside the stated range.
By their numbers in this assay, from the lowest: compounds 1, 2 and 4 (each within the scatter of the next); then compound 3.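

In this assay, trifluoromethyl in place of methoxycarbonyl on this aromatic carbon gives a 6.0-fold lower number from compound 3 to compound 4 (0.78 log units; beyond the scatter), even though the two groups have the same heavy-atom count, so that count alone does not sort the compounds at this position. The comparisons with the other two compounds show no change at the digits printed from compound 2 to compound 4 (within the scatter) and no change at the digits printed from compound 1 to compound 4 (within the scatter), so three different groups at this position now read alike, and among these four compounds methoxycarbonyl alone stands apart. Nothing shown here gives a measured reason for this separation.

The compounds shown leave open whether the higher number belongs to methoxycarbonyl alone or extends to related groups such as a carboxylic acid or ethoxycarbonyl with its longer chain. They also leave open whether an amine on this aromatic carbon would read with compound 3 or with the other three, and whether methoxycarbonyl would stand apart in the same way on another carbon of the ring.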